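Swapping a Halogen for Methyl on the Shared Core

A few compounds are considered here, and "the series" means these few. Any claim that something is new, unique, unknown or untested is made for them only; others in the source may bear on it.

Compound 1 `COc1ccc(-c2csc(N3N=C(c4ccc(F)cc4)CC3c3ccc4c(c3)OCCO4)n2)cc1` gives 4530 nM in a functional assay on MCF7 cells (Homo sapiens) for antiproliferative activity, read by MTT assay, with a stated time of 48 h; on this read-out higher numbers stand for weaker inhibition and lower numbers for stronger inhibition.
Compound 2 `COc1ccc(-c2csc(N3N=C(c4ccc(Cl)cc4)CC3c3ccc4c(c3)OCCO4)n2)cc1` gives 3030 nM in this assay.
Compound 3 `COc1ccc(C2=NN(c3nc(-c4ccc(Br)cc4)cs3)C(c3ccc4c(c3)OCCO4)C2)cc1` gives 2540 nM in this assay.

Among these three numbers compound 2 stands second highest, yet its gaps to both neighbours are small: compound 3 sits a 1.5-fold lower number from compound 1 to compound 2 (0.17 log units; within the scatter) has no counterpart for this pair, so only the two values themselves can be compared, and they lie within the scatter, as do compound 2 and compound 1.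

Compound 4 `COc1ccc(-c2csc(N3N=C(c4ccc(C)cc4)CC3c3ccc4c(c3)OCCO4)n2)cc1` differs from compound 2 in one place: methyl in place of chloro on an aromatic carbon. Among the compounds with values here, no measured pair shows exactly this change. The nearest guide is the halogen swap a 1.5-fold lower number from compound 1 to compound 2 (0.17 log units; within the scatter), which stayed within the scatter. On that basis no step beyond the scatter is expected in this assay either way.

Compound 4 is therefore estimated at 3200 nM, with a range from 1500 nM to 6500 nM, which means an expected step of a 1.1-fold higher number from compound 2 to compound 4 (0.02 log units; within the scatter).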

Compound 4, half-maximal inhibitory concentration: 2680 nM
Compound 4: the middle estimate sits 1.2-fold (0.08 log units) above what was measured; low and high end bracket the measured number.
By their numbers in this assay, from the lowest: compounds 3, 4, 2 and 1 (each within the scatter of the next).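

In this assay the place on the ring that carries chloro in compound 2 now has a non-halogen group to compare: methyl in place of chloro gives a 1.1-fold lower number from compound 2 to compound 4 (0.05 log units; within the scatter) and methyl in place of fluoro gives a 1.7-fold lower number from compound 1 to compound 4 (0.23 log units; within the scatter) on the same read-out. Until now only a swap of one halogen for another could be read here, and this result adds that leaving the halogens for a small carbon group also stays inside the usual scatter, so fluoro, chloro and methyl cannot be told apart at this place. No supporting measurement is available to explain this.

On these data alone, it remains open whether a group of another kind here, such as an amine, a carboxylic acid or a longer chain, would shift the number beyond the scatter.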